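The source may report more compounds than this note shows. Statements on the series, on what has been measured and on what is new or still open speak of the compounds shown alone.

Series notes. Compound 1 `Cc1nc(-c2ccccc2)c(C(=O)N2CCN(c3cccc(C)c3C)CC2)o1` is measured in a functional assay on HL-60 cells (Homo sapiens) for inhibition, read by MTT assay, with a stated time of 72 h (a higher number here means a weaker inhibitor, a lower number a stronger inhibitor), where compound 1 gives 35 nM. Among the two compounds with a reported number compound 1 has the lowest, the nearest being compound 2 `Cc1nc(-c2ccccc2F)c(C(=O)N2CCN(c3cc(Cl)cc(Cl)c3)CC2)o1`, which in this assay gives 60.2 nM; the gap between the two lies within the scatter, so neither is ranked ahead of the other. Compound 3 `CCCc1nc(-c2ccc(OC)cc2)c(C(=O)N2CCN(c3cccc(Cl)c3)CC2)o1` is reported in this assay as "not active" (no number reported), without a number. Within the data shown here, no two measured compounds differ in a single place, so no single-change step is available for orientation.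

Compound 4 `Cc1nc(-c2ccccc2)c(C(=O)N2CCN(c3c(C)cccc3C)CC2)o1` has not yet been measured in this assay. It differs from compound 1 in one place: 2,6-dimethylphenyl in place of 2,3-dimethylphenyl on an amine nitrogen in a ring. The shared core of compound 1 and all other substituents are unchanged. With no measured step of this kind in the series, the expectation rests on compound 1 alone. A step of modest size toward a weaker value is expected for compound 4, with the step of a 1.7-fold higher number from compound 1 to compound 4 (0.23 log units; within the scatter) estimated to stay close to the scatter. For compound 4 in this assay the estimate is 60 nM, with a range from 15 nM to 250 nM.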

Compound 4, half-maximal inhibitory concentration: 146 nM
Estimate against measurement, compound 4: 2.4-fold (0.39 log units) below; the measured number falls inside the stated range.
By their numbers in this assay, from the lowest: compounds 1 and 2 (each within the scatter of the next); then compound 4.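

The two compounds hold the same atoms, so the step from 2,3-dimethylphenyl to 2,6-dimethylphenyl on the amine nitrogen in the ring gives the series its first single-change reading: in this assay, a 4.2-fold higher number from compound 1 to compound 4 (0.62 log units; beyond the scatter). Among these compounds, this shows that the number at this position depends on how the two methyl groups are arranged on the phenyl ring, not only on their presence, and the earlier compounds could not separate that from changes elsewhere in the structure. No measured information bears on the origin of this step.

The compounds shown leave open how this position responds to groups of a different kind on the phenyl ring, such as a single ethyl, a trifluoromethyl or a carboxylic acid, and so whether the arrangement of the substituents matters for anything other than the two methyl groups. They also leave open whether the change from 2,3-dimethylphenyl to 2,6-dimethylphenyl keeps its size and direction when the other substituents on the shared core are different.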